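A branched alkenyl chain on the double-bonded nitrogen

This account rests on a few compounds, and the source may have more. Where it says the series, first, only, none or still open, it means among the compounds named here.

Compound 1, `CCC/N=C(\NC#N)Nc1cccnc1`: 20 mg/kg
Compound 2, `CC(C)/N=C(\NC#N)Nc1cccnc1`: 2.5 mg/kg
Compound 3, `N#CN/C(=N\C1CCCCC1)Nc1cccnc1`: 20 mg/kg

In a functional assay on the whole organism (blood, strain Wistar-Okamoto) with Rattus norvegicus as the target, with a stated time of 5 days (a lower number here means that less compound is needed, a higher number that more compound is needed for the effect), compound 1 stands level with compound 3, and together the two carry the highest numbers of the three; only compound 2 lies apart from them. Compound 4, `C=C(C)C/N=C(\NC#N)Nc1cccnc1`, differs from compound 1 in one place: 1-methylethenyl in place of ethyl on a saturated chain carbon bound to a double-bonded nitrogen. Two measured steps start from compound 1 and bear on it: an 8.0-fold lower number from compound 1 to compound 2 (0.90 log units; beyond the scatter), while no change at the digits printed from compound 1 to compound 3 (within the scatter). Compound 2 carries isopropyl on the double-bonded nitrogen; compound 4 instead keeps the saturated chain carbon bound to that nitrogen and carries the 1-methylethenyl there, as propyl to 2-methylprop-2-en-1-yl. Among the measured compounds shown here, no measured compound carries a chain of this kind, so a step within the scatter is expected, with a slight lean toward a lower number. Compound 4 is therefore estimated at 15 mg/kg, between 5 mg/kg and 40 mg/kg. This expected change amounts to a 1.3-fold lower number from compound 1 to compound 4 (0.12 log units; within the scatter).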

Compound 4, minimum effective dose: 20 mg/kg
For compound 4 the middle estimate is 1.3-fold (0.12 log units) below the measured one; measured number inside the range.
By their numbers in this assay, from the lowest: compound 2; then compounds 1, 3 and 4 (each within the scatter of the next).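

In this assay the 2-methylprop-2-en-1-yl chain on the double-bonded nitrogen reads the same as propyl (no change at the digits printed from compound 1 to compound 4 (within the scatter)) and cyclohexyl (no change at the digits printed from compound 3 to compound 4 (within the scatter)). It does not match isopropyl (an 8.0-fold higher number from compound 2 to compound 4 (0.90 log units; beyond the scatter)), so among these four compounds only the isopropyl of compound 2 stands apart, and adding carbons with a branch on the saturated chain carbon does not reproduce it. Nothing given here accounts for this result. The compounds shown leave open how a tert-butyl or cyclopropyl group on that nitrogen would read, and whether the saturated 2-methylpropyl chain would read like compound 4.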